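Lengthening the Amide Chains of Compound 3

The source may hold more compounds than are shown below. What is called first, only, known or untested is meant among the compounds shown, and "the series" means these compounds.

In a functional assay on B16-F10 cells (Mus musculus) for inhibition, read by MTT assay, with a stated time of 48 h (on this read-out higher numbers stand for weaker inhibition and lower numbers for stronger inhibition), compound 1 (`CCNC(=O)/C=C/c1c(/C=C/c2ccc(OC)cc2)cc(OC)cc1OC`) gives 6990 nM, compound 2 (`CCCCCCCCNC(=O)/C=C/c1c(/C=C/c2ccc(OC)cc2)cc(OC)cc1OC`) gives 8060 nM and compound 3 (`CCCCN(CCCC)C(=O)/C=C/c1c(/C=C/c2ccc(OC)cc2)cc(OC)cc1OC`) gives 9030 nM. Compound 3 thus stands within the scatter of both other compounds. Compound 4 (`CCCCCN(CCCCC)C(=O)/C=C/c1c(/C=C/c2ccc(OC)cc2)cc(OC)cc1OC`) differs from it as follows: dipentylamino in place of dibutylamino on a carbonyl carbon, with dipentylamino in place of dibutylamino on a carbonyl carbon. Three measured amide changes bear on this: a 1.2-fold higher number from compound 1 to compound 2 (0.06 log units; within the scatter), a 1.3-fold higher number from compound 1 to compound 3 (0.11 log units; within the scatter) and a 1.1-fold higher number from compound 2 to compound 3 (0.05 log units; within the scatter), all within the scatter. No step beyond the scatter is therefore expected in this assay, and no direction can be expected with confidence. The estimated step is a 1.1-fold lower number from compound 3 to compound 4 (0.03 log units; within the scatter). For compound 4 the estimated value is 8500 nM, with an expected range of 4800 nM to 15000 nM.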

Compound 4, half-maximal inhibitory concentration: 9270 nM
Compound 4: the middle estimate sits 1.1-fold (0.04 log units) below what was measured; the range from low to high includes it.
By their numbers in this assay, from the lowest: compounds 1, 2, 3 and 4 (each within the scatter of the next).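

On the carbonyl carbon, dipentylamino in place of dibutylamino gives a 1.0-fold higher number from compound 3 to compound 4 (0.01 log units; within the scatter) in this assay, so a second pair of chains with more carbon atoms does not separate from the first. Dipentylamino in place of octylamino gives a 1.2-fold higher number from compound 2 to compound 4 (0.06 log units; within the scatter), and dipentylamino in place of ethylamino gives a 1.3-fold higher number from compound 1 to compound 4 (0.12 log units; within the scatter), so none of the four amide groups shown stands apart from another on this read-out. Nothing available explains this lack of separation. As far as these compounds go, whether a carboxylic acid or a chain carrying an amine at this carbonyl carbon would give a step beyond the scatter remains open.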